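Chain-extended phenoxy analogues across two cores

A few compounds are considered here, and "the series" means these few. Any claim that something is new, unique, unknown or untested is made for them only; others in the source may bear on it.

Compound 1 `N#C/N=C1\N(CCCCCOc2ccc(Cl)cc2)C(=O)C(c2ccccc2)N1c1ccncc1` and compound 2 `N#C/N=C1\N(CCCCCCOc2ccc(Cl)cc2)C(=O)C(c2ccccc2)N1c1ccncc1` share one core; compound 3 `N#C/N=C1\N(CCCCCOc2ccc(Cl)cc2)C(=O)CCN1c1ccncc1` is built on a second core, and the difference between the two cores is not broken down here. In a functional assay on DLD-1 cells (Homo sapiens) for cytotoxicity (on this read-out higher numbers stand for weaker inhibition and lower numbers for stronger inhibition), compound 1 gives 337 nM and compound 2 gives 37 nM. The change between them is (4-chlorophenoxy)methyl in place of 4-chlorophenoxy on a saturated chain carbon, five bonds along the chain from an amide-type nitrogen in a ring and the step it made is a 9.1-fold lower number from compound 1 to compound 2 (0.96 log units; beyond the scatter). Compound 3 gives 6740 nM in this assay, the highest number of the three measured compounds. Compound 4 `N#C/N=C1\N(CCCCCCOc2ccc(Cl)cc2)C(=O)CCN1c1ccncc1` is not yet measured and stands to compound 3 as compound 2 stands to compound 1: (4-chlorophenoxy)methyl in place of 4-chlorophenoxy on a saturated chain carbon, five bonds along the chain from an amide-type nitrogen in a ring. Among the measured compounds shown here, the same change at the same place, now on the second core, is expected to lower the number again, but the precedent is a single pair and the second core sits much higher, so a somewhat smaller step a 6.7-fold lower number from compound 3 to compound 4 (0.83 log units; beyond the scatter) is estimated for compound 4 because the only guide is a 9.1-fold lower number from compound 1 to compound 2 (0.96 log units; beyond the scatter). Compound 4 is therefore expected at 1000 nM, between 300 nM and 3500 nM.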

Compound 4, half-maximal inhibitory concentration: 565 nM
For compound 4 the middle estimate is 1.8-fold (0.25 log units) above the measured one; measured number inside the range.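

In this assay, (4-chlorophenoxy)methyl in place of 4-chlorophenoxy gives a 12-fold lower number from compound 3 to compound 4 (1.08 log units; beyond the scatter), so the change carries over to the core of compound 3 with a step of about the same size as on the core of compound 1: the same change on two cores in this assay, a 9.1-fold lower number (0.96 log units; beyond the scatter) from compound 1 to compound 2 and a 12-fold lower number (1.08 log units; beyond the scatter) from compound 3 to compound 4, 1.3-fold (0.12 log units) apart, within the scatter of two such steps. Within this series, the size of the step therefore does not depend on which of these two cores carries the chain. Among the compounds shown here, the result rests on only two matched pairs and one chain extension, so it does not show that the step would hold on a third core or at other chain lengths, and it does not explain why the number falls.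

Still open, from the compounds shown here alone, is whether a longer chain, such as 2-(4-chlorophenoxy)ethyl at the same place, would lower the number further on both cores or stop doing so. Also open, going by these compounds, is whether the step survives when the 4-chlorophenoxy end is exchanged for another terminal group, such as an amine or a carboxylic acid.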